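The source may report more compounds than this note shows. Statements on the series, on what has been measured and on what is new or still open speak of the compounds shown alone.

Three compounds of the series carry a number in a physicochemical assay for lipophilicity, at pH 7.4 (on this read-out lower numbers stand for lower lipophilicity and higher numbers for higher lipophilicity), so far, and no two of them differ in one place only. Compound 2 (`O=C(Nc1ccc2[nH]c(=O)[nH]c2c1)[C@H]1CCCN1C(=O)C1(c2cccc(Cl)c2)CCCC1`) gives 4.4 on this scale and sits within the scatter of compound 3 (`O=C(Nc1ccc2[nH]ncc2n1)[C@H]1CCCN1C(=O)C1(c2ccc(Cl)cc2)CC(F)(F)C1`), which gives 4.7 in the same measurement. Compound 1 (`COc1ccc(C2(C(=O)N3CCC[C@@H]3C(=O)Nc3ccc4[nH]ncc4n3)CCC2)cc1`) gives 3.9 and lies beneath compound 2 by more than the scatter.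

The next compound to read is compound 4 (`O=C(Nc1ccc2[nH]nnc2c1)[C@H]1CCCN1C(=O)C1(c2cccc(Cl)c2)CCCC1`), which keeps the rest of compound 2 and exchanges one group on an amide-type nitrogen. The whole change is a group of 9 heavy atoms (6 carbon, 3 nitrogen; one five-membered aromatic ring with 3 hetero atoms, one six-membered aromatic ring of carbon only) in place of a group of 10 heavy atoms (7 carbon, 2 nitrogen, 1 oxygen; one five-membered aromatic ring with 2 hetero atoms, one six-membered aromatic ring of carbon only), on an amide-type nitrogen and nothing else in the structure moves. In this assay, going by the values given here, no measured pair shows what such an exchange does, so the expectation rests on the structural change alone and starts from compound 2 at 4.4 as the anchor. The estimated step is a number 0.10 log units higher from compound 2 to compound 4 (within the scatter) and is expected to be slightly upward at most, with nothing beyond the scatter. In this assay compound 4 is expected at 4.5 (estimated range 4.1 to 4.9).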

Compound 4, distribution coefficient: 5.2
Compound 4: middle estimate off by 0.70 log units, on the low side; measured number outside the range, above it.
By their numbers in this assay, from the lowest: compound 1; then compounds 2 and 3 (each within the scatter of the next); then compound 4.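

In this assay, going by these compounds alone, the pair of compound 2 and compound 4 gives the first measured step at this position: a number 0.80 log units higher from compound 2 to compound 4 (beyond the scatter). The change is a group of 9 heavy atoms (one five-membered aromatic ring with 3 hetero atoms, one six-membered aromatic ring of carbon only) in place of a group of 10 heavy atoms (one five-membered aromatic ring with 2 hetero atoms, one six-membered aromatic ring of carbon only), so an exchange on this amide-type nitrogen alone can move the read-out beyond the scatter. The group that leaves has 2 hydrogen-bond donors, 1 hydrogen-bond acceptor and 1 double bond outside aromatic rings, and the group that enters has 1 hydrogen-bond donor and 2 hydrogen-bond acceptors, but no measurement bears on what lies behind the step.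

As far as these compounds go, whether the same exchange gives a similar step with the other parts of the structure, such as those in compound 1 and compound 3, remains open, as this is a single pair. Also open, from the compounds shown here alone, is how this assay responds when a group carrying an amine or a carboxylic acid stands on this amide-type nitrogen.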